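Stereochemical assignment at the ring carbon in a triazole series

The source may report more compounds than this note shows. Statements on the series, on what has been measured and on what is new or still open speak of the compounds shown alone.

Of the compounds shown here, three sharing one core have been measured so far. Compound 1 `Oc1ccc(-c2cn([C@@H]3CN4CCC3CC4)nn2)cc1` gives 461 nM in an assay on HEK293 cells for displacement of a labelled ligand from Neuronal acetylcholine receptor; alpha4/beta2 (Homo sapiens), read by scintillation counting, with a stated time of 120 min; a higher number here means a weaker inhibitor, a lower number a stronger inhibitor. Compound 3 `Fc1ccc(-c2cn(C3CN4CCC3CC4)nn2)cc1` gives 449 nM in this assay. Compound 2 `c1ccc(COc2cccc(-c3cn(C4CN5CCC4CC5)nn3)c2)cc1` gives 668 nM in this assay; this is the highest of the three numbers, but its distance to compound 1 and to compound 3 is within the scatter, so no order among the three can be read from these values. Among the compounds with values here, no step between measured compounds that differ in a single place is available in this set, and compound 1 and compound 3 differ in more than one respect, so their two values can only be taken as they stand.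

Compound 4 `c1ccc(COc2cccc(-c3cn([C@@H]4CN5CCC4CC5)nn3)c2)cc1` is the next compound to be measured. It differs from compound 2 as follows: the two compounds have the same atoms and bonds; at least one stereo element is drawn with a configuration in one of them and without one in the other: 1 of 3 stereo elements differ; a stereocentre at a saturated ring carbon is drawn without a configuration in compound 2 and S in compound 4. The question is whether drawing the S configuration at that ring carbon separates compound 4 from the mixture represented by compound 2. Nothing measured here shows the size of such a step. The expected step from compound 2 to compound 4 is a 1.5-fold lower number from compound 2 to compound 4 (0.17 log units; within the scatter), with a lower number somewhat more likely than a higher one but not beyond the scatter with any confidence. Compound 4 is therefore estimated at 450 nM in this assay, within a range from 200 nM to 950 nM.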

Compound 4, inhibition constant: 414 nM
Compound 4: the middle estimate sits 1.1-fold (0.04 log units) above what was measured, and the stated range covers the measured number.
By their numbers in this assay, from the lowest: compounds 4, 3, 1 and 2 (each within the scatter of the next).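

In this assay, within the data shown here, drawing the S configuration at the saturated ring carbon gives a 1.6-fold lower number from compound 2 to compound 4 (0.21 log units; within the scatter), the first step that can be read at a single place. Compound 4 and compound 2 therefore cannot be told apart in this read-out, so a defined S centre at this position, with this substituent on the shared core, shows no separation from the form drawn without a configuration. The reading rests on a single structural distinction, with atoms and bonds identical in the pair: the fact that one of compounds 2 and 4 is drawn with a defined configuration and the other without, at the place where they differ

Going by these compounds, the R configuration at the same ring carbon remains open, and with it whether the two configurations would lie beyond the scatter of each other, since a form drawn without a configuration gives no separate reading of either one. On these data alone, it is also open whether the same holds when the substituent carried by compound 4 is replaced by an amine or a carboxylic acid, as a single pair cannot show whether this step carries over to other members.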